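A cyano group added to the core of compound 1

This account rests on a few compounds, and the source may have more. Where it says the series, first, only, none or still open, it means among the compounds named here.

In an ADME assay on microsomes from liver (Rattus norvegicus) for metabolic stability, with a stated time of 10 min (on this read-out higher numbers stand for a more stable compound and lower numbers for a less stable compound), compound 1 (`FC(F)(F)c1ccccc1-c1ccc2[nH]c(C3=NOC4(CCCCC4)C3)nc2c1`) gives 75% as the highest of three measured numbers. Compound 2 (`Fc1ccccc1-c1ccc2[nH]c(C3=NOC4(CCCCC4)C3)nc2c1`) gives 55% and compound 3 (`Fc1cccc(C(F)(F)F)c1-c1ccc2[nH]c(C3=NOC4(CCCCC4)C3)nc2c1`) gives 37% on the same read-out. Compound 4 (`N#Cc1cc(-c2ccccc2C(F)(F)F)cc2nc(C3=NOC4(CCCCC4)C3)[nH]c12`) has yet to be measured. It differs from compound 1 on the core (cyano in place of hydrogen on an aromatic carbon), with cyano in place of hydrogen on an aromatic carbon.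

The measured steps bear on this only loosely, since each alters the phenyl group attached to the core and none alters the core itself. They do show how far small swaps can move this number. Fluoro in place of trifluoromethyl gave one modest fall (a number 20 percentage points lower from compound 1 to compound 2 (beyond the scatter)), and trifluoromethyl in place of hydrogen gave another (a number 18 percentage points lower from compound 2 to compound 3 (beyond the scatter)). Fluoro in place of hydrogen gave a large fall (a number 38 percentage points lower from compound 1 to compound 3 (beyond the scatter)).

Going by the values given here, no measured compound sits higher than compound 1, so a modest fall is expected, though a cyano group on the core is untested. The expected change is a step (a number 13 percentage points lower from compound 1 to compound 4 (beyond the scatter)) downward. For compound 4 the estimated value is 62% (expected range 38% to 85%).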

Compound 4, percent of the compound remaining: 96%
Beside the measured number, compound 4's estimate is 34 percentage points below it, outside the stated range (above it).
By their numbers in this assay, from the lowest: compound 3; then compound 2; then compound 1; then compound 4.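

The earlier compounds shown here differ only in the phenyl group attached to the core, so they could not show what a change on the core itself does. In this assay, cyano in place of hydrogen on an aromatic carbon of the core gives a number 21 percentage points higher from compound 1 to compound 4 (beyond the scatter) and shows that this position can carry a new group with a rise in the number, whereas each step listed among compound 1, compound 2 and compound 3 was a fall. Nothing measured here explains why the number rises.

The compounds shown leave open whether another group at this same position, such as an amine, a carboxylic acid or a longer chain, would also raise the number. They also leave open whether cyano would bring a similar rise on the core of compound 2 or compound 3.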